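This account rests on a few compounds, and the source may have more. Where it says the series, first, only, none or still open, it means among the compounds named here.

Compound 2 `Nc1nc(-c2cccc3ccccc23)cn1/N=C/c1cc2ccccc2nc1Cl`: 9480 nM
Compound 1 `COc1ccc(-c2cn(/N=C/c3cc4cc(C)ccc4nc3Cl)c(N)n2)cc1`: 25700 nM

In a functional assay on DLD-1 cells (Homo sapiens) for cytotoxicity, read by MTT assay, with a stated time of 48 h (a higher number here means a weaker inhibitor, a lower number a stronger inhibitor), compound 2 gives 9480 nM, the lower of the two numbers, and its gap to compound 1 is beyond the usual scatter of repeated measurements. Compound 3 `Cc1ccc2nc(Cl)c(/C=N/n3cc(-c4cccc5ccccc45)nc3N)cc2c1` is the unmeasured partner of compound 2. The change from compound 2 to compound 3 is methyl in place of hydrogen on an aromatic carbon. For the measured compounds named here, no pair of measured compounds isolates this change, so there is no measured step to lean on. A methyl group added at a position of this kind is a small change, and no shift beyond the scatter is expected in this assay. Compound 3 is therefore expected to give about 9000 nM, within a range from 3500 nM to 24000 nM, an estimated step of a 1.1-fold lower number from compound 2 to compound 3 (0.02 log units; within the scatter).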

Compound 3, half-maximal inhibitory concentration: 8300 nM
The estimate for compound 3 lay 1.1-fold (0.04 log units) above the measured number; the range from low to high includes it.
By their numbers in this assay, from the lowest: compounds 3 and 2 (each within the scatter of the next); then compound 1.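

In this assay, methyl in place of hydrogen on this aromatic carbon gives a 1.1-fold lower number from compound 2 to compound 3 (0.06 log units; within the scatter), so the added methyl leaves the number unchanged within the scatter. With that methyl present in both compounds, naphthalen-1-yl in place of 4-methoxyphenyl gives a 3.1-fold lower number from compound 1 to compound 3 (0.49 log units; beyond the scatter), a modest step but one beyond the scatter, which the earlier pair could not isolate. No measurement here accounts for either step. From the compounds shown here alone, whether a larger group at the methyl position, such as an amine, a carboxylic acid or a longer chain, would shift the number remains open.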